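Adding a methyl to the oxime ether of compound 3

The source may hold more compounds than are shown below. What is called first, only, known or untested is meant among the compounds shown, and "the series" means these compounds.

Values in an ADME assay on Vero cells (Chlorocebus sabaeus) for cytotoxicity, read by MTT assay, with a stated time of 72 h; a lower number here means that less compound is tolerated, a higher number that more compound is tolerated:
- compound 1 `COc1c(N2CCN(CCC#N)C(C)C2)c(F)cc2c(=O)c(C(=O)O)cn(C3CC3)c12`: 500 ug/mL
- compound 2 `COc1c(N2CCN(CCC(C)=O)C(C)C2)c(F)cc2c(=O)c(C(=O)O)cn(C3CC3)c12`: 9.84 ug/mL
- compound 3 `CO/N=C(\C)CN1CCN(c2c(F)cc3c(=O)c(C(=O)O)cn(C4CC4)c3c2OC)CC1C`: 49.6 ug/mL

Of the three measured compounds, compound 3 stands second highest at 49.6 ug/mL. Compound 4 `CCO/N=C(\C)CN1CCN(c2c(F)cc3c(=O)c(C(=O)O)cn(C4CC4)c3c2OC)CC1C` differs from compound 3 by methyl in place of hydrogen on a saturated chain carbon bound to an oxygen on an unsaturated carbon, so that methoxy becomes ethoxy. Within the data shown here, no measured step makes this same change. The nearest evidence is a 10-fold lower number from compound 1 to compound 3 (1.00 log units; beyond the scatter) and a 5.0-fold higher number from compound 2 to compound 3 (0.70 log units; beyond the scatter), both beyond the scatter, together with a 51-fold lower number from compound 1 to compound 2 (1.71 log units; beyond the scatter), the largest of the three. Each of these exchanges one whole group for another, a larger change than the single methyl entering here, so they offer only a loose outer bound. In this assay, a change within the scatter is therefore expected, with neither direction favoured, although a modest step cannot be ruled out. The expected step is a 1.0-fold higher number from compound 3 to compound 4 (0.00 log units; within the scatter). The estimate for compound 4 is 50 ug/mL, with the measurement expected between 16 ug/mL and 150 ug/mL.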

Compound 4, half-maximal cytotoxic concentration: 31.3 ug/mL
Compound 4: the middle estimate sits 1.6-fold (0.20 log units) above what was measured; low and high end bracket the measured number.
By their numbers in this assay, from the lowest: compound 2; then compounds 4 and 3 (each within the scatter of the next); then compound 1.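

In this assay, among these compounds, the change from methoxy to ethoxy gives a 1.6-fold lower number from compound 3 to compound 4 (0.20 log units; within the scatter), the first reading at this position, and the methyl entering on the saturated chain carbon bound to an oxygen on an unsaturated carbon does not move the number beyond the scatter. The gaps to the other two compounds remain beyond the scatter, with a 3.2-fold higher number from compound 2 to compound 4 (0.50 log units; beyond the scatter) and a 16-fold lower number from compound 1 to compound 4 (1.20 log units; beyond the scatter), so ethoxy, like methoxy, leaves the oxime ether compound apart from both the acetyl and the cyano compounds. No measurement on hand accounts for any of these readings.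

On these data alone, what a longer chain such as propyl, or a benzyl group, would do on this oxygen stays open. So does whether an amine at the end of that chain would keep the number where methoxy and ethoxy put it.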